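Bromo in place of methylcarbamoyl: an expected drop

The source may report more compounds than this note shows. Statements on the series, on what has been measured and on what is new or still open speak of the compounds shown alone.

Two compounds have been measured in an assay for inhibition of Tryptophan 2,3-dioxygenase (Homo sapiens), with stated times of 10 min and 60 min, tested at 100 uM; a higher number here means a stronger effect of the compound at the concentration tested, a lower number a weaker effect:
- compound 1 `FC(F)(F)c1cccc(CNc2cc(C(F)(F)F)cc3[nH]ncc23)c1` gives 74%
- compound 2 `CNC(=O)c1cccc(CNc2cc(C(F)(F)F)cc3[nH]ncc23)c1` gives 91%

For the measured compounds named here, compound 2 stands highest of the two numbers; its nearest neighbour is compound 1, and the one measured step, a number 17 percentage points higher from compound 1 to compound 2 (beyond the scatter), lies beyond the scatter. Going by the values given here, the two differ in a single group on the same aromatic ring, so this step is the only guide for the next change.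

Compound 3 `FC(F)(F)c1cc(NCc2cccc(Br)c2)c2cn[nH]c2c1` keeps the shared core of compound 2 and differs only at that same carbon: bromo in place of methylcarbamoyl on an aromatic carbon. The methylcarbamoyl group leaves and a single bromine atom enters, so compound 3 has, like compound 1, no hydrogen-bond donor or acceptor at this place.

Because the step of a number 17 percentage points higher from compound 1 to compound 2 (beyond the scatter) went up when methylcarbamoyl replaced trifluoromethyl, removing methylcarbamoyl again is expected to reverse much of that gain. The step to compound 3 is therefore estimated as a number 16 percentage points lower from compound 2 to compound 3 (beyond the scatter), downward and of modest size. Compound 3 is expected to give about 75% in this assay, within a range from 55% to 90%.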

Compound 3, a percentage reported as inhibition, at one concentration (the size of the read-out at that concentration, not a potency): 84%
Compound 3: the middle estimate sits 9 percentage points below what was measured; measured number inside the range.
By their numbers in this assay, from the lowest: compounds 1, 3 and 2 (each within the scatter of the next, the first and the last beyond it).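

Measured in this assay, this aromatic carbon turns out not to need the methylcarbamoyl group to keep a high read-out: losing that group with its hydrogen-bond donor and acceptor, and putting a single bromine atom in its place, gives only a small shift (a number 7 percentage points lower from compound 2 to compound 3 (within the scatter)). Bromo and trifluoromethyl also cannot be told apart at this carbon (a number 10 percentage points higher from compound 1 to compound 3 (within the scatter)), so compound 3 lies within the scatter of both other compounds, and only the step between those two stands beyond it (a number 17 percentage points higher from compound 1 to compound 2 (beyond the scatter)). Nothing measured here explains why these three quite different groups give such similar numbers.

The compounds shown leave open whether a carboxylic acid, an amine, a chlorine atom or a longer chain at this carbon would keep the read-out at the same level, or whether plain hydrogen would do so as well. Each number also comes from a single concentration, so compounds that lie close together here could still show a stronger or weaker effect at other concentrations, which only a full concentration series would reveal.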